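A Sulfanyl Ester Side Chain on the Shared Core

The source may report more compounds than this note shows. Statements on the series, on what has been measured and on what is new or still open speak of the compounds shown alone.

In a functional assay on MCF7 cells (Homo sapiens) for inhibition, read by MTT assay, with a stated time of 3 days (a lower number here means a stronger inhibitor, a higher number a weaker inhibitor), compound 1 (`CC[C@H](C)[C@@H](NCC(=O)NNC(=O)COc1ccc(-c2nc3ccccc3s2)cc1OC)C(=O)O`) gives 1790 nM and compound 2 (`CCOC(=O)CN(C)CC(=O)NNC(=O)COc1ccc(-c2nc3ccccc3s2)cc1OC`) gives 1980 nM. Within the data shown here, the one measured step, a 1.1-fold higher number from compound 1 to compound 2 (0.04 log units; within the scatter), lies within the scatter, so compound 2 stands level with its only measured neighbour.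

Compound 3 (`CCOC(=O)[C@H](CS)NCC(=O)NNC(=O)COc1ccc(-c2nc3ccccc3s2)cc1OC`) keeps the shared core and differs from compound 2 on a saturated chain carbon bound to a carbonyl carbon: (1-(ethoxycarbonyl)-2-sulfanylethyl)amino in place of ((ethoxycarbonyl)methyl)(methyl)amino on a saturated chain carbon bound to a carbonyl carbon. It carries (1-(ethoxycarbonyl)-2-sulfanylethyl)amino in place of ((ethoxycarbonyl)methyl)(methyl)amino.

Among the measured compounds shown here, only the step from compound 1 to compound 2 bears on this change, as it involves a swap at the same place. That exchange of substituted amino groups left the number within the scatter, at a 1.1-fold higher number from compound 1 to compound 2 (0.04 log units; within the scatter). For the measured compounds named here, no measured compound carries a sulfanyl group, so the data do not show what this group does here, and the expected range stays wide. In this assay the expected step is a 1.1-fold lower number from compound 2 to compound 3 (0.04 log units; within the scatter), which is not expected to exceed the scatter. The estimate for compound 3 is 1800 nM, with an expected range of 800 nM to 4000 nM.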

Compound 3, half-maximal inhibitory concentration: 2880 nM
Compound 3: middle estimate off by 1.6-fold (0.20 log units), on the low side; measured number inside the range.
By their numbers in this assay, from the lowest: compounds 1, 2 and 3 (each within the scatter of the next).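

In this assay the entry of (1-(ethoxycarbonyl)-2-sulfanylethyl)amino gives a 1.5-fold higher number from compound 2 to compound 3 (0.16 log units; within the scatter) and so shows that a sulfanyl group can stand on this side chain without a step beyond the scatter. Set against the acid-bearing chain, 1-(ethoxycarbonyl)-2-sulfanylethyl in place of 1-carboxy-2-methylbutyl on an amine nitrogen gives a 1.6-fold higher number from compound 1 to compound 3 (0.21 log units; within the scatter) and also stays inside it, so all three substituted amino groups now stand level in this assay and none of the changes shown at this position moves the number measurably. The data offer no independent measurement that could explain this result, and nothing given here accounts for the numbers.

As far as these compounds go, what the sulfanyl group contributes on its own stays open, since it enters together with a change in the rest of the amino group, and a hydroxyl or a methylsulfanyl on the same chain would be needed to separate the two. From the compounds shown here alone, it is also open whether a carboxylic acid in place of the ethyl ester on this chain, a plain amine, or a much longer chain at this carbon would shift the number beyond the scatter.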